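The compounds below may be only part of what the source reports. "The series", "measured", "known", "first", "only" and "open" are said of these compounds alone.

Of the compounds shown here, three sharing one core have been measured in an ADME assay on microsomes from liver (Homo sapiens) for metabolic stability, tested at 2.5 uM; on this read-out higher numbers stand for fast clearance and lower numbers for slow clearance. Compound 1 `O=S(=O)(c1ccc(F)c(F)c1)c1cnc2cc(F)ccc2c1-c1cccc(F)c1` gives 0.6 mL/min, compound 2 `O=S(=O)(c1cc(F)cc(F)c1)c1cnc2cc(F)ccc2c1-c1cccc(F)c1` gives 0.06 mL/min, and compound 3 `Cc1ccc(S(=O)(=O)c2cnc3cc(F)ccc3c2-c2cccc(F)c2)cc1F` gives 0.41 mL/min, the second highest of the three numbers. Two earlier changes on the sulfonyl sulfur bear on the next step: a 10-fold lower number from compound 1 to compound 2 (1.00 log units; beyond the scatter), and a 6.8-fold higher number from compound 2 to compound 3 (0.83 log units; beyond the scatter). Compound 4 `COc1ccc(S(=O)(=O)c2cnc3cc(F)ccc3c2-c2cccc(F)c2)cc1` differs from compound 3 only at that position: 4-methoxyphenyl in place of 3-fluoro-4-methylphenyl on a sulfonyl sulfur. Both earlier swaps on the sulfonyl sulfur moved the read-out by modest amounts, one down and one up, so a shift of similar size in either direction is possible, and compound 4 is expected to change by a 1.5-fold higher number from compound 3 to compound 4 (0.17 log units; within the scatter). In this assay compound 4 is estimated at 0.6 mL/min, with a likely range from 0.2 mL/min to 1.8 mL/min.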

Compound 4, intrinsic clearance in a liver preparation (reported as CLH), per the amount of preparation that the assay uses: 2.94 mL/min
The estimate for compound 4 lay 4.9-fold (0.69 log units) below the measured number; the whole stated range lies below it.
By their numbers in this assay, from the lowest: compound 2; then compounds 3 and 1 (each within the scatter of the next); then compound 4.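

In this assay, the step to 4-methoxyphenyl on the sulfonyl sulfur gives a 7.2-fold higher number from compound 3 to compound 4 (0.86 log units; beyond the scatter), as well as a 4.9-fold higher number from compound 1 to compound 4 (0.69 log units; beyond the scatter) and a 49-fold higher number from compound 2 to compound 4 (1.69 log units; beyond the scatter). Compound 4 therefore stands clear of all three compounds with a fluorine-bearing ring at this position, showing that this swap can raise the number and widening the spread seen here. Nothing measured here explains that rise.

The compounds shown do not separate the gain of the methoxy group from the loss of fluorine. From the compounds shown here alone, how a dimethylamino group or a longer ether chain would read here also remains open.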